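Cytotoxicity notes: chloro in place of isopropyl

The source may report more compounds than this note shows. Statements on the series, on what has been measured and on what is new or still open speak of the compounds shown alone.

Compound 1 `CC(C)c1ccc(Cn2cncc2CNc2ccc(-c3nc4ccccc4s3)c(-c3ccccc3)c2)cc1`: > 1000 nM (a limit)
Compound 2 `Cc1cccc(-c2cccc(NCc3cncn3Cc3ccccc3)c2)c1C`: > 1000 nM (a limit)
Compound 3 `CC(C)c1cccc(NCc2cncn2Cc2ccccc2)c1`: > 1000 nM (a limit)

In a toxicity assay on NIH3T3 cells (Mus musculus) for cytotoxicity, read by resazurin assay (on this read-out higher numbers stand for an effect only at larger amounts of compound and lower numbers for an effect already at smaller amounts), compound 1 gives > 1000 nM, which is a limit of the assay and not a number. Compound 2 likewise stands at a limit, > 1000 nM. Compound 3 also stands at a limit, > 1000 nM. All three sit at the limit of > 1000 nM in this assay, at which 3 of the 3 values shown sit, so none can be set above or below another. Within the data shown here, the one step between measured compounds, a step that the two limits leave unreadable from compound 2 to compound 3, stays unreadable between two limits.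

Compound 4 `Clc1ccc(Cn2cncc2CNc2ccc(-c3nc4ccccc4s3)c(-c3ccccc3)c2)cc1` differs from compound 1 by chloro in place of isopropyl on an aromatic carbon. Among the measured compounds shown here, no measured step tests this change; the series so far shows no effect up to the limit with either arm. Compound 4 is therefore expected to stay near the limit, estimated at 3000 nM with a range from 1000 nM to 10000 nM. The expected step that the limit leaves unreadable from compound 1 to compound 4 is none beyond the scatter.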

Compound 4, half-maximal effective concentration: > 1000 nM
Compound 4 gave a limit, no number; the forecaster's own chance of this, stated with the estimate: 85%; the middle value is on the limit's open side.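

Compound 1 and compound 4 both stand at a limit, so no step between them can be read: the limit of > 1000 nM in this assay, at which 4 of the 4 values shown sit.

The compounds shown leave open where any of them would reach a half-maximal effect, and so whether chloro and isopropyl differ at all.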